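Bromo for methoxy on the benzoyl end of a fluoro/methoxy indole pair

A few compounds are considered here, and "the series" means these few. Any claim that something is new, unique, unknown or untested is made for them only; others in the source may bear on it.

Four compounds share a core in which a propyl-linked indole and a substituted benzoyl group are joined through two piperazines and a glycinamide bridge. Compound 1 is `COc1cccc(C(=O)N2CCN(CC(=O)N3CCN(CCCc4c[nH]c5ccc(F)cc45)CC3)CC2)c1`, compound 2 is `O=C(CN1CCN(C(=O)c2cccc(Br)c2)CC1)N1CCN(CCCc2c[nH]c3ccc(F)cc23)CC1`, compound 3 is `COc1cccc(C(=O)N2CCN(CC(=O)N3CCN(CCCc4c[nH]c5ccc(OC)cc45)CC3)CC2)c1`, and compound 4, not yet measured, is `COc1ccc2[nH]cc(CCCN3CCN(C(=O)CN4CCN(C(=O)c5cccc(Br)c5)CC4)CC3)c2c1`.

In an ADME assay on HEK293 cells (Homo sapiens) for cytotoxicity, read by MTT assay, with a stated time of 72 h (a lower number here means a stronger inhibitor, a higher number a weaker inhibitor), compound 1 gives 87100 nM. In this assay compound 2 gives 40600 nM. For compound 3 the result in this assay is a limit of the assay, > 200000 nM; this is the limit noted as the limit of > 200000 nM in this assay, at which 1 of the 3 values shown sits.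

Two differences are counted between the measured compounds. The change from compound 1 to compound 2 is bromo in place of methoxy on an aromatic carbon, and the step that went with it was a 2.1-fold lower number from compound 1 to compound 2 (0.33 log units; beyond the scatter). The cores of compound 1 and compound 3 differ by methoxy in place of fluoro on an aromatic carbon, with the step of an at least 2.2-fold higher number from compound 1 to compound 3 (0.36 log units; beyond the scatter).

Compound 4 carries the same kind of change as compound 2 did, now on the core of compound 3: bromo in place of methoxy on an aromatic carbon. The place lines of the two changes read the same, word for word. Because compound 3 sits at the limit (the limit of > 200000 nM in this assay, at which 1 of the 3 values shown sits), only a direction can be taken from compound 3; the size is borrowed from the step of a 2.1-fold lower number from compound 1 to compound 2 (0.33 log units; beyond the scatter). The expected step from compound 3 to compound 4 is therefore an at least 1.3-fold lower number from compound 3 to compound 4 (0.12 log units; that floor lies within the scatter), and compound 4 is estimated at 150000 nM in this assay, between 70000 nM and 400000 nM, with a fair chance that the assay again reports only a limit.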

Compound 4, half-maximal inhibitory concentration: 57000 nM
Beside the measured number, compound 4's estimate is 2.6-fold (0.42 log units) above it, outside the stated range (below it).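

In this assay, the change from 3-methoxyphenyl to 3-bromophenyl keeps its direction on the core of compound 3, with an at least 3.5-fold lower number from compound 3 to compound 4 (0.54 log units; beyond the scatter), and the two cores compare as follows: the same change on two cores in this assay, a 2.1-fold lower number (0.33 log units; beyond the scatter) from compound 1 to compound 2 and an at least 3.5-fold lower number (0.54 log units; beyond the scatter) from compound 3 to compound 4; the limit leaves it open whether they differ

Compound 3 is reported only as a limit of the assay, > 200000 nM, and the size of the step on its core therefore stays unread, so these two cores show a shared direction but not a shared size.

The other change, methoxy in place of fluoro on the other aromatic end, gives a 1.4-fold higher number from compound 2 to compound 4 (0.15 log units; within the scatter) on the bromo-bearing core, and its comparison with the first core is likewise unsettled: the same change on two cores in this assay, an at least 2.2-fold higher number (0.36 log units; beyond the scatter) from compound 1 to compound 3 and a 1.4-fold higher number (0.15 log units; within the scatter) from compound 2 to compound 4; the limit leaves it open whether they differ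

Still open, from the compounds shown here alone, is whether the direction of the change holds for a chloro or a trifluoromethyl group in the same place on the benzoyl group, since the series here covers only bromo and methoxy at that point. Also open, going by these compounds, is how this assay would read with a longer chain in place of the propyl link, or with an amine or a carboxylic acid on either aromatic end of the shared core.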